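This account rests on a few compounds, and the source may have more. Where it says the series, first, only, none or still open, it means among the compounds named here.

Of the compounds shown here, two sharing one core have so far been tested in a functional assay on DU-145 cells (Homo sapiens) for inhibition, read by trypan blue exclusion, with a stated time of 96 h; on this read-out higher numbers stand for weaker inhibition of growth and lower numbers for stronger inhibition of growth. In this test, compound 1 `O=C(/C(=C\c1ccc(Br)cc1)S(=O)(=O)c1ccc(Br)cc1)c1ccc(Br)cc1` gives 10000 nM, and compound 2 `O=C(/C(=C\c1ccc(F)cc1F)S(=O)(=O)c1ccc(Br)cc1)c1ccc(Br)cc1` gives 7500 nM. Compound 2 has the lower of these two numbers, but the gap lies within the scatter of repeated measurements, so the two cannot truly be ranked. Both need fairly high concentrations to inhibit cell growth in this test.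

The next compound, compound 3 `COc1cccc(OC)c1/C=C(\C(=O)c1ccc(Br)cc1)S(=O)(=O)c1ccc(Br)cc1`, keeps the rest of compound 2 and changes one group: 2,6-dimethoxyphenyl in place of 2,4-difluorophenyl on a double-bonded chain carbon bound to a double-bonded chain carbon. The swap is 2,6-dimethoxyphenyl in place of 2,4-difluorophenyl, on a double-bonded chain carbon bound to a double-bonded chain carbon. Among the compounds with values here, only one measured change bears on this place, the step of a 1.3-fold lower number from compound 1 to compound 2 (0.12 log units; within the scatter), and it stays within the scatter. Within the data shown here, that is thin evidence, and no compound tested so far carries a methoxy group, so the range must stay wide. No shift beyond the scatter is expected in this assay, and no direction can be favoured. The expected change is a 1.1-fold lower number from compound 2 to compound 3 (0.03 log units; within the scatter).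

For compound 3 the estimated value is 7000 nM, with an expected range from 2500 nM to 15000 nM.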

Compound 3, concentration for 50% growth inhibition: 10000 nM
The estimate for compound 3 lay 1.4-fold (0.15 log units) below the measured number; low and high end bracket the measured number.
By their numbers in this assay, from the lowest: compounds 2, 1 and 3 (each within the scatter of the next).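

Methoxy groups now appear at this position for the first time, and the new compound still cannot be separated from the earlier two: in this assay the swap to 2,6-dimethoxyphenyl gives a 1.3-fold higher number from compound 2 to compound 3 (0.12 log units; within the scatter) and, set against the 4-bromophenyl group, gives no change at the digits printed from compound 1 to compound 3 (within the scatter) (both steps within the scatter). Across these three compounds, then, a bromine, two fluorines or two methoxy groups on the phenyl ring on this double-bonded chain carbon make no difference that can be read, even though the entering group brings 2 hydrogen-bond acceptors where the 2,4-difluorophenyl group has 0. Nothing measured here offers an explanation for this flat result.

As far as these compounds go, all three compounds keep a substituted phenyl ring at this place, so it remains open whether a phenyl ring carrying an amine or a carboxylic acid, or a longer chain in place of the ring, would move the number beyond the scatter. From the compounds shown here alone, the two 4-bromophenyl groups elsewhere on the shared core are the same throughout, so what a change at either of them would do also remains open.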